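The compounds below may be only part of what the source reports. "The series", "measured", "known", "first", "only" and "open" are said of these compounds alone.

Three compounds have so far been measured in a functional assay on the whole organism (artery, strain albino) with Rattus norvegicus as the target, with a stated time of 60 min, at a dose of 10 mg/kg by the oral route; a higher number here means more inhibition at the dose given (going by the name of the read-out), a lower number less inhibition:

compound 1, `COc1ccc(C2N=C(SCc3ccc(Cl)cc3)NC(C)=C2C(=O)Nc2ccc(Br)cc2)cc1`, gives 12.3%.
compound 2, `COc1ccc(C2N=C(SCc3ccc(F)cc3)NC(C)=C2C(=O)Nc2ccc(Br)cc2)cc1`, gives 8.7%.
compound 3, `CC1=C(C(=O)Nc2ccc([N+](=O)[O-])cc2)C(c2ccc(Br)cc2)N=C(SCc2ccc(Cl)cc2)N1`, gives 10.8%.

Compound 1 and compound 2 share one core and differ in a single place: fluoro in place of chloro on an aromatic carbon. In this assay the step of a number 3.6 percentage points lower from compound 1 to compound 2 (within the scatter), so the two numbers cannot be told apart with confidence. Compound 3 rests on a different core; how that core differs from the core of compound 1 is not broken down here. Its value sits within the scatter of both compound 1 and compound 2, so none of the three can be set above or below the others.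

The unmeasured compound 4, `CC1=C(C(=O)Nc2ccc([N+](=O)[O-])cc2)C(c2ccc(Br)cc2)N=C(SCc2ccc(F)cc2)N1`, stands to compound 3 exactly as compound 2 stands to compound 1: fluoro in place of chloro on an aromatic carbon. The surroundings of the changed position read the same in both pairs, so this is the same change, made a second time on the other core. The expectation for compound 4 rests on the step already seen, a number 3.6 percentage points lower from compound 1 to compound 2 (within the scatter), and the step from compound 3 to compound 4 in this assay is therefore expected to be a number 3.3 percentage points lower from compound 3 to compound 4 (within the scatter), a move that stays inside the usual scatter. Compound 4 is accordingly estimated to give 7.5%, with a plausible range from 0% to 17%.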

Compound 4, a percentage reported as inhibition, in the whole organism at one dose (the size of the read-out at that dose, not a potency): 9.7%
For compound 4 the middle estimate is 2.2 percentage points below the measured one; measured number inside the range.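

On the second core, the replacement of chloro by fluoro gives, in this assay, a number 1.1 percentage points lower from compound 3 to compound 4 (within the scatter). Set beside the same change on the first core, the result shows no difference between the two cores that the data can resolve: the same change on two cores in this assay, a number 3.6 percentage points lower (within the scatter) from compound 1 to compound 2 and a number 1.1 percentage points lower (within the scatter) from compound 3 to compound 4, 2.5 percentage points apart, within the scatter of two such steps. Among these compounds, the change from 4-chlorobenzyl to 4-fluorobenzyl can therefore be carried from one core to the other without any step leaving the scatter, but this does not show that the change has a real effect of its own, or that the two steps truly share a direction and size, as neither step can be told apart from repeat variation and only two cores are covered.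

The compounds shown leave open what happens when something other than a halogen stands at this position, for example an amine or a carboxylic acid on the aromatic ring, or when a longer chain replaces the (4-chlorobenzyl)sulfanyl group. They also leave open whether the same comparison would hold at any other dose or time, as all of these readings come from a single dose and a single stated time.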